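Adding a Fluorine to a Compound Without Measurable Inhibition

The compounds below may be only part of what the source reports. "The series", "measured", "known", "first", "only" and "open" are said of these compounds alone.

Compound 1, `Fc1ccc(Oc2[nH]cnc3ncnc2-3)cc1`, was tested in an assay on isolated protein for inhibition of RAC-alpha serine/threonine-protein kinase (Homo sapiens), tested at 30 uM (a higher number here means more inhibition at the concentration tested (going by the name of the read-out), a lower number less inhibition), where compound 1 gives 0%. Compound 2, `c1ccc(Sc2ncnc3[nH]cnc23)cc1`, shares the same core and in this assay compound 2 gives 0%. On the numbers shown, compound 2 stands level with compound 1 at the digits printed; its nearest neighbour is compound 1, and the two values show no difference beyond the usual scatter. Neither compound shows inhibition at the single concentration tested.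

Compound 3, `Fc1ccc(Sc2ncnc3[nH]cnc23)cc1`, has not yet been measured. Compared with compound 2, the change is fluoro in place of hydrogen on an aromatic carbon. For the measured compounds named here, no measured pair with exactly this change exists here, so the size of the step can only be guessed. Since compound 2 shows no inhibition, as 0% shows, and compound 1 is at the same level, the expected step of no change at the digits printed from compound 2 to compound 3 (within the scatter) is none beyond the scatter. Compound 3 is therefore expected to give about 0% in this assay, with a range from -8% to 10%.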

Compound 3, a percentage reported as inhibition, at one concentration (the size of the read-out at that concentration, not a potency): 0%
Beside the measured number, compound 3's estimate shows no gap at the digits printed; measured number inside the range.
By their numbers in this assay, from the lowest: compounds 1, 2 and 3 (each within the scatter of the next).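

Fluoro in place of hydrogen on an aromatic carbon, para to a large group, gives no change at the digits printed from compound 2 to compound 3 (within the scatter) in this assay and is the first single-place step available for this series. Compound 2 gives 0% and compound 3 gives 0%, so this step begins and ends with no measurable inhibition at the one concentration tested, and it cannot show whether fluoro would alter inhibition in a compound that already has some. No independent measurement is available to explain this result.

From the compounds shown here alone, it remains open whether another group at this position, such as an amine, a carboxylic acid or a longer chain, would give any inhibition in this assay at all. Going by these compounds, it also remains open whether the same exchange of hydrogen for fluoro would leave the read-out unchanged on a related compound that starts from a measurable level of inhibition.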